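The source may report more compounds than this note shows. Statements on the series, on what has been measured and on what is new or still open speak of the compounds shown alone.

Compound 1 `COc1ccc(C2=NN(C3=NC(c4ccccc4)CS3)C(c3cccc4ccccc34)C2)cc1` is one of two compounds tested in a functional assay on BGC-823 cells (Homo sapiens) for inhibition, read by CCK-8 assay, with a stated time of 48 h; a lower number here means a stronger inhibitor, a higher number a weaker inhibitor. In this assay compound 1 gives 9510 nM, the lower of the two numbers. Within the data shown here, its only neighbour is compound 2 `Fc1ccc(C2=NN(C3=NC(c4ccccc4)CS3)C(c3cccc4ccccc34)C2)cc1`, which in this assay gives 22700 nM; the step of a 2.4-fold higher number from compound 1 to compound 2 (0.38 log units; beyond the scatter) comes from a fluoro in place of methoxy on an aromatic carbon. Compound 3 `COc1ccc(C2=NN(C3=NC(c4ccccc4)CS3)C(c3ccc4ccccc4c3)C2)cc1` has not yet been measured. It differs from compound 1 in a single place: naphthalen-2-yl in place of naphthalen-1-yl on a saturated ring carbon. Among the measured compounds shown here, none of the measured steps touches this part of the molecule, so the only measured change concerns a different group and gives no direct guide. With nothing to point either way, the expectation is a step no larger than the usual scatter, a 1.0-fold lower number from compound 1 to compound 3 (0.00 log units; within the scatter). Compound 3 is therefore estimated at 9500 nM, within a range from 3000 nM to 30000 nM.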

Compound 3, half-maximal inhibitory concentration: 7250 nM
For compound 3 the middle estimate is 1.3-fold (0.12 log units) above the measured one; the range from low to high includes it.
By their numbers in this assay, from the lowest: compounds 3 and 1 (each within the scatter of the next); then compound 2.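

Placing naphthalen-2-yl instead of naphthalen-1-yl on the saturated ring carbon gives a 1.3-fold lower number from compound 1 to compound 3 (0.12 log units; within the scatter) in this assay. Among these compounds, this is the first measured change at this position, and it shows that the two ways of joining this group give numbers that cannot be told apart here. The pair therefore gives no reason to prefer either attachment in this assay, and nothing available explains why the two numbers agree.

On these data alone, it remains open how far this carbon depends on a naphthalenyl group at all, for example whether a group carrying an amine or a carboxylic acid would keep the number in the same range. As far as these compounds go, it is also open whether the two attachments would still read alike with fluoro in place of the methoxy group on the other aromatic ring.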